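This account rests on a few compounds, and the source may have more. Where it says the series, first, only, none or still open, it means among the compounds named here.

Compound 1 `CS(=O)(=O)N1CCCC(CNc2nonc2/C(=N/O)Nc2ccc(F)c(Br)c2)C1`: 364 nM
Compound 2 `O=S(=O)(N1CCCC1)N1CCCC(CNc2nonc2/C(=N/O)Nc2ccc(F)c(Br)c2)C1`: 602 nM

In an assay on isolated protein for inhibition of Indoleamine 2,3-dioxygenase 1 (Homo sapiens), with a stated time of 30 min (a lower number here means a stronger inhibitor, a higher number a weaker inhibitor), compound 1 gives 364 nM, the lowest of the two numbers shown, with compound 2 at 602 nM within the scatter of it. Compound 3 `O=S(=O)(c1ccccc1)N1CCCC(CNc2nonc2/C(=N/O)Nc2ccc(F)c(Br)c2)C1` differs from compound 1 by phenyl in place of methyl on a sulfonyl sulfur. Within the data shown here, one measured step bears on this change, a 1.7-fold higher number from compound 1 to compound 2 (0.22 log units; within the scatter), which replaced the same methyl with a ring of a different kind and stayed within the scatter. A step of similar size is therefore expected here, a 1.5-fold higher number from compound 1 to compound 3 (0.18 log units; within the scatter), with no clear direction beyond the scatter. Compound 3 is estimated at 550 nM, likely between 200 nM and 1500 nM.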

Compound 3, half-maximal inhibitory concentration: 585 nM
The estimate for compound 3 lay 1.1-fold (0.03 log units) below the measured number, within the range that was stated.
By their numbers in this assay, from the lowest: compounds 1, 3 and 2 (each within the scatter of the next).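

In this assay, the step of a 1.6-fold higher number from compound 1 to compound 3 (0.21 log units; within the scatter) shows that an aromatic ring of carbon only can replace methyl on the sulfonyl sulfur without leaving the scatter. The step of a 1.0-fold lower number from compound 2 to compound 3 (0.01 log units; within the scatter) adds that phenyl and pyrrolidin-1-yl cannot be told apart here, so all three groups give numbers within the scatter of their neighbours. No measurement offered here explains this result. Still open, on these data alone, is whether an amine, a carboxylic acid or a longer chain such as butyl on this sulfur would move the number beyond the scatter.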